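This account rests on a few compounds, and the source may have more. Where it says the series, first, only, none or still open, it means among the compounds named here.

Three compounds sharing one core were tested in an ADME assay on MT4 cells (Homo sapiens) for cytotoxicity, read by MTT assay, with a stated time of 5 days; on this read-out higher numbers stand for lower toxicity in this test and lower numbers for higher toxicity in this test. Compound 1 `COc1cc2nc(SCC(=O)Nc3ccc(F)cc3)nc(Nc3c(C)cc(/C=C/C#N)cc3C)c2cc1OC` gives >= 150000 nM in this assay, and that value is a limit of the test rather than a measured number. Compound 2 `COc1cc2nc(SCC(=O)Nc3ccc(Cl)cc3)nc(Nc3c(Cl)cc(/C=C/C#N)cc3Cl)c2cc1OC` gives 29500 nM in this assay. Compound 3 `COc1cc2nc([S+]([O-])CC(=O)Nc3cccc(Cl)c3)nc(Nc3c(Cl)cc(/C=C/C#N)cc3Cl)c2cc1OC` gives 68900 nM in this assay. Of the two values that are numbers, compound 3 stands highest, and its nearest neighbour is compound 2, with a gap between them that lies beyond the usual scatter of repeated measurements. The remaining value is the one described by the limit of >= 150000 nM in this assay, at which 1 of the 3 values shown sits, so it cannot be placed in this order.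

Compound 4 `COc1cc2nc([S+]([O-])CC(=O)Nc3cccc(S(N)(=O)=O)c3)nc(Nc3c(Cl)cc(/C=C/C#N)cc3Cl)c2cc1OC` has not yet been measured in this assay. It differs from compound 3 in a single place: sulfamoyl in place of chloro on an aromatic carbon. Within the data shown here, no pair of measured compounds shows this same change, so the expectation rests only on where compound 3 stands. A step of modest size in the upward direction is expected, a 1.4-fold higher number from compound 3 to compound 4 (0.14 log units; within the scatter), close to the edge of the scatter. Compound 4 is therefore expected to give about 95000 nM in this assay, with a likely range from 35000 nM to 200000 nM, and some chance that only a limit is reported.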

Compound 4, half-maximal cytotoxic concentration: 67800 nM
Compound 4: the middle estimate sits 1.4-fold (0.15 log units) above what was measured, within the range that was stated.
By their numbers in this assay, from the lowest: compound 2; then compounds 4 and 3 (each within the scatter of the next). At a limit, above all of these: compound 1.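

In this assay, sulfamoyl in place of chloro on an aromatic carbon, meta to a large group, gives a 1.0-fold lower number from compound 3 to compound 4 (0.01 log units; within the scatter), so the two compounds cannot be told apart on this read-out. This is the only pair shown that differs in one place, and it gives the first direct reading at this position: a single chlorine is replaced by a group of 4 heavy atoms carrying 1 hydrogen-bond donor and 2 hydrogen-bond acceptors, and the number stays within the scatter of repeated measurements. The values shown offer no measurement that explains this result.

Among these compounds, with only this one swap at this position, it remains open whether an amine, a carboxylic acid or a longer chain such as propyl would also stay within the scatter of these two compounds. Going by these compounds, it also remains open whether sulfamoyl in place of chloro would read the same way on the otherwise different structures of compound 1 or compound 2.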